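Swapping a dichlorophenyl for a dimethoxyphenyl on the chalcone ketone

A few compounds are considered here, and "the series" means these few. Any claim that something is new, unique, unknown or untested is made for them only; others in the source may bear on it.

Measured compounds:
compound 1 `COc1ccc(-c2cc(/C=C/C(=O)c3ccc(OC)c(OC)c3)[nH]n2)cc1` — 106%
compound 2 `COc1cc(-c2cc(/C=C/C(=O)c3ccc(Cl)c(Cl)c3)[nH]n2)cc(OC)c1OC` — 89%
compound 3 `COc1ccc(-c2cc(/C=C/C(=O)c3cc(OC)c(OC)c(OC)c3)[nH]n2)cc1OC` — 73%

In a functional assay on SR cells (Homo sapiens) for cytotoxicity, read by sulforhodamine B assay, with a stated time of 48 h, tested at 0.1 uM (on this read-out higher numbers stand for a weaker effect at the one concentration tested and lower numbers for a stronger effect), compound 2 gives 89%, the second highest of the three numbers; compound 3 lies below it and compound 1 above it, both gaps beyond the usual scatter. Compound 4 `COc1ccc(C(=O)/C=C/c2cc(-c3cc(OC)c(OC)c(OC)c3)n[nH]2)cc1OC` has not yet been measured. It differs from compound 2 in one place: 3,4-dimethoxyphenyl in place of 3,4-dichlorophenyl on a carbonyl carbon. For the measured compounds named here, no single-point step between measured compounds is available to anchor the size of this change, and the values of compound 1 and compound 3 bracket compound 2 on either side. A modest step in either direction, possibly none beyond the scatter, is expected from compound 2 to compound 4, as a number 4 percentage points lower from compound 2 to compound 4 (within the scatter). The estimate for compound 4 is 85%, with a range from 60% to 108%.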

Compound 4, a percentage reported as activity, at one concentration (the size of the read-out at that concentration, not a potency): 81%
Compound 4: middle estimate off by 4 percentage points, on the high side; the range from low to high includes it.
By their numbers in this assay, from the lowest: compounds 3, 4 and 2 (each within the scatter of the next, the first and the last beyond it); then compound 1.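

In this assay, for the compounds shown here, the change on this carbonyl carbon, 3,4-dimethoxyphenyl in place of 3,4-dichlorophenyl, gives a number 8 percentage points lower from compound 2 to compound 4 (within the scatter) and is the first change here seen alone, since no earlier pair differed in just one place. At this one concentration, the read-out therefore does not separate the two groups, although the count of hydrogen-bond acceptors in the group rises from none to two. Nothing available explains this result.

Going by these compounds, whether a phenyl carrying an amine or a carboxylic acid on this carbonyl carbon would move the number beyond the scatter remains open. So does whether the same swap would behave alike at other concentrations.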